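A Trifluoromethyl Step Against an Assay Limit

The source may hold more compounds than are shown below. What is called first, only, known or untested is meant among the compounds shown, and "the series" means these compounds.

In a functional assay on CEM-SS cells (Homo sapiens) for cytotoxicity (on this read-out lower numbers stand for stronger inhibition and higher numbers for weaker inhibition), compound 1 `Clc1cc2nc(Br)n(Cc3ccccc3)c2cc1Cl` gives > 100000 nM, which is a limit of the assay and not a number. Compound 2 `FC(F)(F)c1ccc(Cn2c(Br)nc3cc(Cl)c(Cl)cc32)cc1` gives > 100000 nM, which is likewise a limit. Compound 3 `FC(F)(F)c1cccc(Cn2c(Br)nc3cc(Cl)c(Cl)cc32)c1` has not yet been measured, and its change from compound 1 is trifluoromethyl in place of hydrogen on an aromatic carbon. Among the measured compounds shown here, only one measured step bears on this change, the same exchange of groups seen in a step that the two limits leave unreadable from compound 1 to compound 2, and its size cannot be read. Both measured compounds stand at the limit of > 100000 nM in this assay, at which 2 of the 2 values shown sit. On the basis of compound 2 and a step that the two limits leave unreadable from compound 1 to compound 2, no step beyond the scatter is expected in this assay, and no direction can be given. The expected step is a number no higher from compound 1 to compound 3 (the limit leaves the size open). Compound 3 is estimated at 100000 nM, with an expected range from 40000 nM to 200000 nM.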

Compound 3, half-maximal inhibitory concentration: > 100000 nM
Compound 3 gave a limit, no number; the forecaster's own chance of this, stated with the estimate: 85%; the middle value sits exactly at the limit.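

Compound 1 and compound 3 both stand at a limit of this assay, not at a number, and no new step can be read between them. The compounds shown leave open what number any of them would give, and whether trifluoromethyl in place of hydrogen on an aromatic carbon changes that number at all.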